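A few compounds are considered here, and "the series" means these few. Any claim that something is new, unique, unknown or untested is made for them only; others in the source may bear on it.

Compound 1 `COc1cc(N)c(Cl)cc1C(=O)NC1CCNCC1` carries only a hydrogen on the amine nitrogen of its saturated ring. In a functional assay on HEK293 cells for activation of 5-hydroxytryptamine receptor 4 (Homo sapiens), read by cAMP accumulation (a lower number here means a smaller maximal response, a higher number a larger maximal response), compound 1 reaches > 100%, which is a limit of the assay rather than a number. That position is the limit of > 100% in this assay, at which 2 of the 3 values shown sit. Two further compounds share a different core. Compound 2 `CC(C)n1c(=O)n(C(=O)NCC2CCNCC2)c2ccccc21` gives 92% in this assay. Compound 3 `CC(C)n1c(=O)n(C(=O)NCCN2CCNCC2)c2ccccc21` gives > 100% in this assay, again a limit of the assay. For the measured compounds named here, the single measured step, a number at least 8 percentage points higher from compound 2 to compound 3 (that floor lies within the scatter), alters the basic amine itself and not a substituent on a ring nitrogen, so it bears only loosely on the change now considered. Compound 4 `CCCCCN1CCC(NC(=O)c2cc(Cl)c(N)cc2OC)CC1` differs from compound 1 by pentyl in place of hydrogen on an amine nitrogen in a ring. Going by the values given here, no measured step tests an alkyl substituent on that nitrogen. Compound 4 is expected to remain a strong activator, with an estimated value of 95% (from 75% to 110%). The expected step of a number at least 5 percentage points lower from compound 1 to compound 4 (that floor lies within the scatter) is thus estimated to lie within the scatter or only slightly below it.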

Compound 4, intrinsic activity: the largest response reached, in percent of the reference agonist's: > 100%
Compound 4 gave a limit, no number; the forecaster's own chance of this, stated with the estimate: 35%; middle value at least 5 percentage points away from the limit.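

Compound 4 gives > 100% in this assay, also a limit of the assay, so no step can be read between compound 1 and compound 4, because both sit at the same limit: the limit of > 100% in this assay, at which 3 of the 4 values shown sit.

The compounds shown leave open whether pentyl on an amine nitrogen in a ring changes the maximal response at all, and by how much.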